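Swapping the imidazole tail for a piperazine tail

The source may hold more compounds than are shown below. What is called first, only, known or untested is meant among the compounds shown, and "the series" means these compounds.

Of the compounds shown here, three that share one core have been tested. Compound 1 `O=C1c2c[n+]([O-])c3ccccc3c2C(=O)c2c1c1ccccc1n2CCCCn1ccnc1` carries a four-carbon chain ending in an imidazole ring. In a functional assay on MCF7 cells (Homo sapiens) for cytotoxicity, read by MTT assay, with a stated time of 72 h (on this read-out lower numbers stand for stronger inhibition and higher numbers for weaker inhibition), compound 1 gives 130 nM. Compound 2 `O=C1c2c[n+]([O-])c3ccccc3c2C(=O)c2c1c1ccccc1n2Cc1cn([C@@H]2C[C@H](O)[C@@H](CO)O2)nn1` gives 110 nM in this assay, and compound 3 `CC1(C)OCC(Cn2cc(Cn3c4c(c5ccccc53)C(=O)c3c[n+]([O-])c5ccccc5c3C4=O)nn2)O1` gives 290 nM. Among these numbers compound 1 stands second highest: compound 2 sits nearest to it, with a gap that lies within the usual scatter of repeated measurements, while compound 3 sits furthest from it, beyond that scatter.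

Among the measured compounds shown here, the only measured step between two compounds that differ in one place is a 2.6-fold higher number from compound 2 to compound 3 (0.42 log units; beyond the scatter), where a dioxolane-bearing group replaces a sugar-like ring on an aromatic nitrogen.

Compound 4 `O=C1c2c[n+]([O-])c3ccccc3c2C(=O)c2c1c1ccccc1n2CCCCN1CCNCC1` differs from compound 1 at the end of the chain: piperazin-1-yl in place of 1H-imidazol-1-yl on a saturated chain carbon, four bonds along the chain from an aromatic nitrogen. For the measured compounds named here, no measured step concerns a change at this place; the one available step concerns a different position and a different pair of groups, so it gives no direct guidance here. With nothing in the measurements that points to a shift in either direction, the expectation is a step from compound 1 to compound 4 of about no change at the digits printed from compound 1 to compound 4 (within the scatter), that is, no change beyond the scatter. Compound 4 is therefore estimated to give 130 nM in this assay, with a range from 50 nM to 350 nM.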

Compound 4, half-maximal inhibitory concentration: 12000 nM
For compound 4 the middle estimate is 92-fold (1.97 log units) below the measured one, outside the stated range (above it).
By their numbers in this assay, from the lowest: compounds 2 and 1 (each within the scatter of the next); then compound 3; then compound 4.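

In this assay, piperazin-1-yl in place of 1H-imidazol-1-yl gives a 92-fold higher number from compound 1 to compound 4 (1.97 log units; beyond the scatter), so the group at the end of the four-carbon chain has a very large effect on this read-out. Among the compounds shown here, no earlier step touched this place. The exchange looks small on paper: a five-membered aromatic ring gives way to a six-membered non-aromatic ring, the group gains a hydrogen-bond donor, and neither group carries a net charge. Nothing measured here ties the step to any one of these differences.

The compounds shown leave open whether the weaker result goes with the loss of the aromatic ring or with the hydrogen on the piperazine ring nitrogen; 4-methylpiperazin-1-yl, which has a methyl group on that nitrogen, and morpholin-4-yl, which has an oxygen in its place, would help to separate these two readings, as would 1H-pyrazol-1-yl, another aromatic ring. On these data alone, it also remains open whether a longer chain carrying the piperazine ring would give a different result in this assay from that of compound 4.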